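The compounds below may be only part of what the source reports. "The series", "measured", "known", "first", "only" and "open" are said of these compounds alone.

Measured so far in a functional assay on A549 cells (Homo sapiens) for inhibition; on this read-out higher numbers stand for weaker inhibition and lower numbers for stronger inhibition:
compound 1 `O=C1C=CC(OCC(F)(F)F)N1c1ccc(C(F)(F)F)cc1` — 8390 nM
compound 2 `O=C1C=CC(OCC(F)(F)F)N1c1ccccc1` — 23400 nM
compound 3 `O=C1C=CC(OCC(F)(F)F)N1c1ccccc1F` — 44900 nM

Compound 2 gives 23400 nM in this assay, the second highest of the three numbers. Its nearest neighbour is compound 3: the step from compound 2 to compound 3 is a 1.9-fold higher number from compound 2 to compound 3 (0.28 log units; within the scatter). Its furthest is compound 1: from compound 1 to compound 2 the step is a 2.8-fold higher number from compound 1 to compound 2 (0.45 log units; beyond the scatter).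

Compound 4 `O=C1C=CC(OCC(F)(F)F)N1c1ccc(Br)cc1` has not yet been measured. Against compound 2 its difference is bromo in place of hydrogen on an aromatic carbon, on a six-membered aromatic ring of carbon only, para to a large group. Going by the values given here, the step that bears on it is the one from compound 1 to compound 2, a 2.8-fold higher number from compound 1 to compound 2 (0.45 log units; beyond the scatter), where a trifluoromethyl on an aromatic carbon went with the lower number. The fluoro of compound 3 stayed within the scatter and gives little guidance. A modest step downward is therefore expected, roughly a 2.3-fold lower number from compound 2 to compound 4 (0.37 log units; beyond the scatter). For compound 4 the expected value in this assay is 10000 nM, with a range of 4000 nM to 28000 nM.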

Compound 4, half-maximal inhibitory concentration: 6960 nM
Compound 4: the middle estimate sits 1.4-fold (0.16 log units) above what was measured, and the stated range covers the measured number.
By their numbers in this assay, from the lowest: compounds 4 and 1 (each within the scatter of the next); then compounds 2 and 3 (each within the scatter of the next).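

In this assay, going by these compounds alone, bromo on the aromatic carbon para to a large group gives a 3.4-fold lower number from compound 2 to compound 4 (0.53 log units; beyond the scatter), so trifluoromethyl is no longer the only group at this place that stands apart from hydrogen beyond the scatter. The direct exchange of trifluoromethyl for bromo gives a 1.2-fold lower number from compound 1 to compound 4 (0.08 log units; within the scatter), which leaves the two groups indistinguishable on this read-out. The lower number relative to hydrogen is therefore not particular to trifluoromethyl, although two groups are too few to define a trend at this position.

Going by these compounds, it remains open whether the same step appears with other groups on this carbon, such as a methoxy, an amine or a carboxylic acid, and whether bromo would give it on other carbons of the ring. No supporting measurement is available to explain the steps at this position.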